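This account rests on a few compounds, and the source may have more. Where it says the series, first, only, none or still open, it means among the compounds named here.

Compound 1 `COc1cccc(OC)c1C(=O)Nc1c[nH]nc1C(=O)NC1CC2CCC1C2` is measured in an ADME assay on MRC5 cells (Homo sapiens) for inhibition, with a stated time of 72 h (a higher number here means that more compound is needed for the effect, a lower number that less compound is needed), where compound 1 gives only a limit, > 50000 nM, and not a number. Two of the three values shown sit at that same point, as stated in the limit of > 50000 nM in this assay, at which 2 of the 3 values shown sit. Compound 3 `CO[C@H]1CC[C@H](NC(=O)c2n[nH]cc2NC(=O)C2CCOCC2)CC1` also returns a limit in this assay, > 50000 nM. Going by the values given here, the single numerical value shown belongs to compound 2 `CO[C@H]1CC[C@H](NC(=O)c2n[nH]cc2NC(=O)c2ccccc2C(F)(F)F)CC1`, which gives 3300 nM in this assay. Compound 1 therefore stands at the edge of what this assay can report, with compound 2 alone showing a measurable value.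

Compound 4 `COc1cccc(OC)c1C(=O)Nc1c[nH]nc1C(=O)NC1CCCCC1` differs from compound 1 in one place: a group of 6 heavy atoms (6 carbon; one six-membered non-aromatic ring of carbon only) in place of a group of 7 heavy atoms (7 carbon; 2 five-membered non-aromatic rings of carbon only), on an amide-type nitrogen. Among the compounds with values here, no measured step between two compounds separated by a single change is available here, so the size of this move can only be expected rather than read from a neighbour. The step from compound 1 to compound 4 is expected to be small, a number no higher from compound 1 to compound 4 (the limit leaves the size open), leaving compound 4 close to the limit where compound 1 sits. Compound 4 is accordingly expected to give about 50000 nM in this assay, within a range from 15000 nM to 150000 nM.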

Compound 4, half-maximal effective concentration: 35000 nM
Estimate against measurement, compound 4: 1.4-fold (0.15 log units) above; measured number inside the range.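

Going by these compounds alone, on the amide-type nitrogen, putting cyclohexyl in place of the group with 2 five-membered non-aromatic rings gives the first step that can be read in this assay: an at least 1.4-fold lower number from compound 1 to compound 4 (0.15 log units; that floor lies within the scatter). With the rest of the molecule unchanged, this one position is enough to turn a limit into a number, although the printed floor of the step does not go beyond the scatter. The step is only a floor because compound 1 stands at a limit, so its true size remains unknown: the limit of > 50000 nM in this assay, at which 2 of the 4 values shown sit.

The compounds shown leave open how the number moves at this nitrogen with other groups, such as a cyclopentyl ring, a longer alkyl chain or a ring carrying an amine. They also do not tell whether this step would hold with a different group on the other amide of the core.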